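Solubility across a shared diarylalkyne hydroxamate series

This account rests on a few compounds, and the source may have more. Where it says the series, first, only, none or still open, it means among the compounds named here.

Of the compounds shown here, three have been measured so far in a physicochemical assay for solubility; a lower number here means a less soluble compound, a higher number a more soluble compound. Compound 1 `O=C(NC1(C(=O)NO)CCCCC1)c1ccc(C#Cc2ccccc2)cc1` gives < 1000 nM in this assay, which is a limit of the measurement rather than a number (the limit of < 1000 nM in this assay, at which 1 of the 3 values shown sits). Compound 2 `NC(=O)C[C@H](NC(=O)c1ccc(C#Cc2ccccc2)cc1)C(=O)NO` gives 61000 nM in this assay, the highest of the two numbers reported. Compound 3 `O=C(NC1(C(=O)NO)CCOCC1)c1ccc(C#Cc2ccccc2)cc1` gives 5000 nM in this assay, a value that stands clearly lower than that of compound 2, beyond the usual scatter.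

Compound 4 `O=C(CNC(=O)c1ccc(C#Cc2ccccc2)cc1)NO` has not yet been measured in this assay. It differs from compound 2 in one place: hydrogen in place of carbamoylmethyl on a saturated chain carbon bound to an amide-type nitrogen and a carbonyl carbon. The carbamoylmethyl group that leaves carries one hydrogen-bond donor and one hydrogen-bond acceptor, and nothing is put in its place beyond a hydrogen atom. For the measured compounds named here, no measured pair isolates this change, so its size must be judged from the spread of the values at hand.

The expectation is that compound 4 falls below compound 2 in this assay, with a step of a 4.1-fold lower number from compound 2 to compound 4 (0.61 log units; beyond the scatter) that is expected to exceed the scatter but to stay short of the gap down to compound 3. The estimated solubility of compound 4 is 15000 nM, within a range from 3000 nM to 60000 nM.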

Compound 4, solubility: 21000 nM
The estimate for compound 4 lay 1.4-fold (0.15 log units) below the measured number; the measured number falls inside the stated range.
By their numbers in this assay, from the lowest: compound 3; then compound 4; then compound 2. At a limit, below all of these: compound 1.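

The series now has its first pair differing in one place, and in this assay the change of carbamoylmethyl to hydrogen on a saturated chain carbon bound to an amide-type nitrogen and a carbonyl carbon gives a 2.9-fold lower number from compound 2 to compound 4 (0.46 log units; beyond the scatter). For the compounds shown here, this places a size on the change at this position, which the earlier compounds could not do: the step is modest but beyond the scatter, and compound 4, with only hydrogen on this carbon, still reads 21000 nM. No measured property on hand bears on why the number moves with this change.

This is a single pair on a single core, so it gives a step for this one change and no trend for the position. Open, as far as these compounds go, is how other groups on the same carbon would read against compound 4 and compound 2, for example a plain methyl group, a carboxylic acid, a primary amine or a longer chain, and whether the same change would give a step of similar size on a different core.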